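A few compounds are considered here, and "the series" means these few. Any claim that something is new, unique, unknown or untested is made for them only; others in the source may bear on it.

Measured so far in a functional assay on PC-3 cells (Homo sapiens) for inhibition, read by sulforhodamine B assay, with a stated time of 48 h, tested at 50 uM; a higher number here means more inhibition of growth at the concentration tested, a lower number less inhibition of growth:
- compound 1 `COc1ccccc1/C=C/C(=O)/C=C/c1ccc(OCc2cn(CCCOc3cc(=O)oc4ccccc34)nn2)c(OC)c1` gives "not active" (no number reported)
- compound 2 `COc1cccc(/C=C/C(=O)/C=C/c2ccc(OCc3cn(CCCCOc4cc(=O)oc5ccccc45)nn3)c(OC)c2)c1` gives "not active" (no number reported)
- compound 3 `COc1cc(/C=C/C(=O)/C=C/c2cc(OC)c(OC)c(OC)c2)ccc1OCc1cn(CCOc2cc(=O)oc3ccccc23)nn1` gives 22%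

Compound 3 stands alone here, since it is the only one of the three with a number, 22%, while the other two gave none. The next compound to be tested is compound 4 `COc1ccc(/C=C/C(=O)/C=C/c2ccc(OCc3cn(CCOc4cc(=O)oc5ccccc45)nn3)c(OC)c2)cc1`, which takes 4-methoxyphenyl in place of 3,4,5-trimethoxyphenyl on a double-bonded chain carbon bound to a double-bonded chain carbon. Among the measured compounds shown here, no measured pair isolates this change, so the expectation is tentative. Compound 1 ("not active" (no number reported)) and compound 2 ("not active" (no number reported)) also lack the 3,4,5-trimethoxyphenyl group, though they differ from compound 3 elsewhere too. In this assay a small downward step is therefore expected, probably not beyond the usual scatter, and a report of no activity would be no surprise. The estimate corresponds to an expected a number 8 percentage points lower from compound 3 to compound 4 (within the scatter). For compound 4 the estimated growth inhibition is 14%, with an expected range from 2% to 30%.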

Compound 4, percent growth inhibition at one concentration: 15%
For compound 4 the middle estimate is 1 percentage points below the measured one; low and high end bracket the measured number.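

In this assay, 4-methoxyphenyl in place of 3,4,5-trimethoxyphenyl on a double-bonded chain carbon bound to a double-bonded chain carbon gives a number 7 percentage points lower from compound 3 to compound 4 (within the scatter). This single-place comparison shows that, on this core, the 3,4,5-trimethoxyphenyl group is not required for a reported number, and that the exchange does not separate the two compounds beyond the scatter. Nothing measured here explains this result.

The compounds shown leave open whether an amine or a carboxylic acid at this place would shift growth inhibition beyond the scatter. They also leave open what the length of the chain in the shared core does on its own, as compound 1 and compound 2 each differ from compound 3 and compound 4 in more than one place.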